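Cyano Substitution on the Aryl Ring of Compound 2

A few compounds are considered here, and "the series" means these few. Any claim that something is new, unique, unknown or untested is made for them only; others in the source may bear on it.

Measured so far in a functional assay on THP-1 cells (Homo sapiens) for inhibition, read by ELISA, with stated times of 1 h and 18 h; a higher number here means a weaker inhibitor, a lower number a stronger inhibitor:
Compound 1, `NC(=O)[C@@H]1[C@H](Nc2nc(Nc3cccc(C(=O)N4CCCC4)c3)ncc2-c2cccnc2)[C@H]2C=C[C@@H]1C2`, gives 320 nM.
Compound 2, `NC(=O)[C@@H]1[C@H](Nc2nc(Nc3cccc(C(=O)N4CCCC4)c3)ncc2-c2ccccc2)[C@H]2C=C[C@@H]1C2`, gives 220 nM.
Compound 3, `NC(=O)[C@@H]1[C@H](Nc2nc(Nc3cccc(C(=O)N4CCCC4)c3)ncc2-c2cncc(F)c2)[C@H]2C=C[C@@H]1C2`, gives 170 nM.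

Among these three numbers compound 2 stands second highest; its nearest neighbour is compound 3, since a 1.3-fold lower number from compound 2 to compound 3 (0.11 log units; within the scatter), and its furthest is compound 1, since a 1.5-fold lower number from compound 1 to compound 2 (0.16 log units; within the scatter). The third step, a 1.9-fold lower number from compound 1 to compound 3 (0.27 log units; within the scatter), is likewise within the scatter, so the three compounds cannot be ordered on these numbers.

Compound 4, `N#Cc1ccc(-c2cnc(Nc3cccc(C(=O)N4CCCC4)c3)nc2N[C@H]2[C@@H](C(N)=O)[C@@H]3C=C[C@H]2C3)cc1`, is reached from compound 2 by cyano in place of hydrogen on an aromatic carbon. Going by the values given here, no measured pair shows this cyano group, so nothing bears on it directly; the only related information is that exchanging or decorating the aryl ring at this position, as in a 1.5-fold lower number from compound 1 to compound 2 (0.16 log units; within the scatter) and a 1.3-fold lower number from compound 2 to compound 3 (0.11 log units; within the scatter), left this assay unchanged beyond the scatter. For compound 4 the step of a 1.1-fold lower number from compound 2 to compound 4 (0.04 log units; within the scatter) is therefore expected to stay within the scatter, in no clear direction. Compound 4 is estimated at 200 nM, with a range from 70 nM to 600 nM.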

Compound 4, half-maximal inhibitory concentration: 190 nM
Compound 4: the middle estimate sits 1.1-fold (0.02 log units) above what was measured; the range from low to high includes it.
By their numbers in this assay, from the lowest: compounds 3, 4, 2 and 1 (each within the scatter of the next).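

In this assay the 4-cyanophenyl group brings the first nitrile to this position, on an aromatic carbon para to a large group, and a 1.2-fold lower number from compound 2 to compound 4 (0.06 log units; within the scatter) shows that adding it keeps the result within the scatter. The comparisons with the two pyridine compounds, a 1.1-fold higher number from compound 3 to compound 4 (0.05 log units; within the scatter) and a 1.7-fold lower number from compound 1 to compound 4 (0.23 log units; within the scatter), also stay within the scatter, so the phenyl, pyridin-3-yl, 5-fluoropyridin-3-yl and 4-cyanophenyl groups cannot be ordered at this position. No available evidence accounts for this lack of separation.

The compounds shown leave open whether a nitrile elsewhere on the ring would give the same picture. They also do not show whether an amine or a carboxylic acid on this ring, or a morpholine in place of the ring, would move the number beyond the scatter.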